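The source may report more compounds than this note shows. Statements on the series, on what has been measured and on what is new or still open speak of the compounds shown alone.

Working notes on the series in an ADME assay on HepG2 cells (Homo sapiens) for cytotoxicity, read by MTT assay, with a stated time of 72 h; on this read-out lower numbers stand for higher toxicity in this test and higher numbers for lower toxicity in this test. Compound 1 `Cc1ccc(-c2cc3nc(NCc4ccccc4Cl)[nH]c(=O)c3s2)cc1` gives 32600 nM. Compound 2 `CC(C)(C)Nc1nc2c(-c3ccc(F)cc3)csc2c(=O)[nH]1` gives 2300 nM. Compound 3 `CC(C)Nc1nc2c(-c3ccc(F)cc3)csc2c(=O)[nH]1` reads > 15600 nM, which is a limit of the assay and not a number. Compound 3 therefore has no exact position on the scale, and the next comparison starts from that limit.

The next compound is compound 4 `COc1ccc(-c2csc3c(=O)[nH]c(NC(C)C)nc23)cc1`, which carries methoxy in place of fluoro on an aromatic carbon, para to a large group: methoxy in place of fluoro on an aromatic carbon.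

Among the measured compounds shown here, the only measured step between compounds that differ in one place is an at least 6.7-fold higher number from compound 2 to compound 3 (0.83 log units; beyond the scatter). That step, beyond the scatter, is hydrogen in place of methyl on a saturated chain carbon. It does not involve the aromatic carbon changed here, so it bears on the new change only indirectly and gives no size or direction for it. For the measured compounds named here, no measured step replaces fluoro with methoxy. With no evidence for a shift, no step beyond the scatter is expected in this assay, and compound 4 may also return only a limit.

The estimated value for compound 4 is 18000 nM, with an expected range of 6000 nM to 50000 nM. This estimate means an expected step that the limit leaves unreadable from compound 3 to compound 4.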

Compound 4, half-maximal cytotoxic concentration: 27800 nM
The estimate for compound 4 lay 1.5-fold (0.19 log units) below the measured number; measured number inside the range.
By their numbers in this assay, from the lowest: compound 2; then compounds 4 and 1 (each within the scatter of the next).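

The step from compound 3 to compound 4, methoxy in place of fluoro on an aromatic carbon, cannot be read in this assay, since the value of compound 3 is a limit of the assay and not a number: the limit of > 15600 nM in this assay, at which 1 of the 4 values shown sits.

The compounds shown leave open whether this change shifts the read-out at all, and in which direction.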